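Chloro to Trifluoromethyl on the Sulfonyl Ring of Compound 2

A few compounds are considered here, and "the series" means these few. Any claim that something is new, unique, unknown or untested is made for them only; others in the source may bear on it.

Measured so far:
Compound 1 `COc1cccc(N2CCN(c3ccc(C(=O)/C=C/c4ccc(Cl)cc4)cc3)CC2)c1`: 2.28%
Compound 2 `O=C(/C=C/c1ccc(Cl)cc1)c1ccc(N2CCN(S(=O)(=O)c3ccc(Cl)cc3)CC2)cc1`: 56.6%

In a functional assay on the whole organism (strain Kunming) for inhibition, with Mus musculus as the target, with a stated time of 1 h, at a dose of 40 mg/kg by the oral route (on this read-out higher numbers stand for more inhibition at the one dose given (going by the name of the read-out) and lower numbers for less inhibition), compound 1 gives 2.28%. Compound 2 gives 56.6%, the highest of the two numbers. For the measured compounds named here, the one measured step, a number 54.3 percentage points higher from compound 1 to compound 2 (beyond the scatter), changed the group on the amine nitrogen in the ring, not the ring now in question.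

Compound 3 `O=C(/C=C/c1ccc(Cl)cc1)c1ccc(N2CCN(S(=O)(=O)c3ccc(C(F)(F)F)cc3)CC2)cc1` differs from compound 2 in one place: trifluoromethyl in place of chloro on an aromatic carbon. Going by the values given here, no measured step touches this position, so nothing here shows how such an exchange shifts the read-out; the only guide is that the closest neighbour, compound 2, sits high.

The expectation is therefore a step of a number 6.6 percentage points lower from compound 2 to compound 3 (within the scatter), that is, no change beyond the scatter. Compound 3 is estimated at 50%, within a range from 25% to 75%.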

Compound 3, a percentage reported as inhibition, in the whole organism at one dose (the size of the read-out at that dose, not a potency): 59.6%
The estimate for compound 3 lay 9.6 percentage points below the measured number; the range from low to high includes it.
By their numbers in this assay, from the lowest: compound 1; then compounds 2 and 3 (each within the scatter of the next).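

In this assay, putting trifluoromethyl in place of chloro on this aromatic carbon gives a number 3 percentage points higher from compound 2 to compound 3 (within the scatter), so this read-out does not separate the two groups. For the compounds shown here, the earlier step changed the whole group on the ring amine nitrogen, whereas this pair is the first look at the sulfonyl ring itself: at this position, the high read-out survives an exchange of chloro for the bigger trifluoromethyl. The data offer no measurement that could explain why the two groups read alike.

Going by these compounds, both groups tested here contain a halogen, so it remains open whether an amine or a carboxylic acid on this carbon would keep the read-out as high. With only one dose shown, it also remains open whether compound 2 and compound 3 would still read alike at other doses.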